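A few compounds are considered here, and "the series" means these few. Any claim that something is new, unique, unknown or untested is made for them only; others in the source may bear on it.

Compound 1 `CCCCCCCCN(C)C(=O)Cn1cc(Cc2cnc(OCC)nc2)c(=O)nc1SCc1ccc(F)cc1` gives 7% in a functional assay on a cell-free system (plasma, Oryctolagus cuniculus) for inhibition of platelet-activating factor acetylhydrolase (Homo sapiens), tested at 100 nM; a higher number here means more inhibition at the concentration tested (going by the name of the read-out), a lower number less inhibition.
Compound 2 `CCCCCCCCN(C)C(=O)Cn1cc(Cc2cnc(=O)n(CC)c2)c(=O)nc1SCc1ccc(F)cc1` gives 5%.
Compound 3 `CCCCCCCCN(C)C(=O)Cn1cc(Cc2cnc(=O)n(CC(=O)O)c2)c(=O)nc1SCc1ccc(F)cc1` gives 27%.

Compound 3 stands highest of the three, and both gaps lie beyond the scatter: a number 20 percentage points higher from compound 1 to compound 3 (beyond the scatter) and a number 22 percentage points higher from compound 2 to compound 3 (beyond the scatter). Compound 4 `CCCCCCCCN(C)C(=O)Cn1cc(Cc2cnc(=O)n(CC(=O)NC)c2)c(=O)nc1SCc1ccc(F)cc1` differs from compound 3 by methylamino in place of hydroxy on a carbonyl carbon.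

For the measured compounds named here, only one measured step touches this arm: a number 22 percentage points higher from compound 2 to compound 3 (beyond the scatter), where carboxy replaced methyl. Going by the values given here, no measured step exchanges hydroxy for methylamino, so its direction is not known from these data. Compound 4 keeps the carbonyl and a hydrogen-bond donor but not the hydroxy, so a small change, most likely downward and near the scatter, is expected: a number 7 percentage points lower from compound 3 to compound 4 (within the scatter). Compound 4 is estimated at 20%, with a range from 5% to 35%.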

Compound 4, a percentage reported as inhibition, at one concentration (the size of the read-out at that concentration, not a potency): 42%
Compound 4: the middle estimate sits 22 percentage points below what was measured; the whole stated range lies below it.
By their numbers in this assay, from the lowest: compounds 2 and 1 (each within the scatter of the next); then compound 3; then compound 4.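

On this arm, the carboxy group is not needed to lift the number in this assay: methylamino in place of hydroxy gives a number 15 percentage points higher from compound 3 to compound 4 (beyond the scatter) and so puts the amide ahead of the acid. The other two comparisons, a number 37 percentage points higher from compound 2 to compound 4 (beyond the scatter) and a number 35 percentage points higher from compound 1 to compound 4 (beyond the scatter), are the largest steps in this set. Nothing here explains why the amide outdoes the acid. Still open, as far as these compounds go, is whether amino or dimethylamino on the same carbonyl carbon would match methylamino, which would show whether the amide hydrogen and the methyl each matter.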